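Moving the Furan Attachment Point on the Ester of Compound 3

The source may hold more compounds than are shown below. What is called first, only, known or untested is meant among the compounds shown, and "the series" means these compounds.

Measured compounds:
compound 1 `CC(=O)C1=C(C)NC(=O)NC1c1ccoc1` gives 6%
compound 2 `CCN(CC)C(=O)C1=C(C)NC(=O)NC1c1ccoc1` gives 15%
compound 3 `CC1=C(C(=O)OCC2CC2)C(c2ccco2)NC(=O)N1` gives 29%

All three were tested in an assay on membranes from CHO cells for displacement of a labelled ligand from adenosine receptor A1 (Homo sapiens), read by scintillation counting, with a stated time of 60 min, tested at 1 uM; on this read-out higher numbers stand for more inhibition at the one concentration tested (going by the name of the read-out) and lower numbers for less inhibition. Compound 3 stands highest of the three: compound 2 gives 15% and compound 1 gives 6%, and both lie further below compound 3 than repeated measurements usually stray. Going by the values given here, the only step measured between two compounds that differ in one place is a number 9 percentage points higher from compound 1 to compound 2 (within the scatter), a change at the carbonyl carbon that stays within the scatter and says nothing about the furan.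

Compound 4 `CC1=C(C(=O)OCC2CC2)C(c2ccoc2)NC(=O)N1` keeps the cyclopropylmethyl ester of compound 3 and differs from it by furan-3-yl in place of furan-2-yl on a saturated ring carbon. Among the compounds with values here, compounds 1 and 2 already carry furan-3-yl, but each paired with a different carbonyl group, so no measured step isolates this swap on its own. With nothing to guide direction or size, the expectation for compound 4 in this assay is a step of roughly a number 5 percentage points lower from compound 3 to compound 4 (within the scatter) from compound 3, which is not beyond the scatter. Compound 4 is therefore estimated at 24%, with a range from 8% to 40%.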

Compound 4, a percentage reported as inhibition, at one concentration (the size of the read-out at that concentration, not a potency): 29%
Compound 4: middle estimate off by 5 percentage points, on the low side; low and high end bracket the measured number.
By their numbers in this assay, from the lowest: compounds 1 and 2 (each within the scatter of the next); then compounds 3 and 4 (each within the scatter of the next).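

In this assay, furan-3-yl in place of furan-2-yl on the saturated ring carbon gives no change at the digits printed from compound 3 to compound 4 (within the scatter) on the cyclopropylmethyl ester, so with this ester the furan attachment point makes no readable difference at the one concentration tested. With furan-3-yl held constant, the carbonyl group can now be compared on its own: cyclopropylmethoxy in place of diethylamino gives a number 14 percentage points higher from compound 2 to compound 4 (beyond the scatter) and cyclopropylmethoxy in place of methyl gives a number 23 percentage points higher from compound 1 to compound 4 (beyond the scatter) in the same assay, which sets the ester apart from both of those groups among these furan-3-yl compounds. No measurement offered here bears on the reason for either result.

As far as these compounds go, the furan swap can be read only on the cyclopropylmethyl ester, so whether it would also leave the number unchanged with diethylamino or methyl on the carbonyl carbon remains open. Also open, from the compounds shown here alone, is what a phenyl ring or a thiophene ring would do on the saturated ring carbon, or how a longer chain such as n-butyl would compare with cyclopropylmethyl on the ester.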